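A few compounds are considered here, and "the series" means these few. Any claim that something is new, unique, unknown or untested is made for them only; others in the source may bear on it.

Compound 2, `Cc1ccc(S(=O)(=O)NC(=O)Nc2ccccc2C(=O)/C=C/c2cccc(O)c2)cc1`, gives 39.3 ug/mL in an ADME assay on the whole organism for cytotoxicity, with Artemia salina as the target, with a stated time of 24 h (a higher number here means that more compound is needed for the effect, a lower number that less compound is needed), the higher of the two numbers at hand; compound 1, `CCc1cc(/C=C/C(=O)c2ccccc2NC(=O)NS(=O)(=O)c2ccc(C)cc2)cc(OC)c1OC`, gives 19.2 ug/mL in this assay. Among the compounds with values here, the one measured step, a 2.0-fold higher number from compound 1 to compound 2 (0.31 log units; beyond the scatter), shows that replacing the more substituted phenyl with a bare hydroxyphenyl raised the number by a modest margin. Compound 3, `COc1cc(/C=C/C(=O)c2ccccc2NC(=O)NS(=O)(=O)c2ccc(C)cc2)ccc1O`, takes the opposite direction in part: 4-hydroxy-3-methoxyphenyl in place of 3-hydroxyphenyl on a double-bonded chain carbon bound to a double-bonded chain carbon. Within the data shown here, only the step from compound 1 to compound 2 bears on this change, and it was modest; since compound 3 puts a methoxy group back onto the ring while keeping a hydroxyl, a number between those of compound 1 and compound 2 seems the most natural expectation. Compound 3 is therefore expected to give about 28 ug/mL in this assay, a step of a 1.4-fold lower number from compound 2 to compound 3 (0.15 log units; within the scatter), with a plausible range from 14 ug/mL to 56 ug/mL.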

Compound 3, concentration for half-maximal effect: 17.8 ug/mL
Compound 3: middle estimate off by 1.6-fold (0.20 log units), on the high side; the measured number falls inside the stated range.
By their numbers in this assay, from the lowest: compounds 3 and 1 (each within the scatter of the next); then compound 2.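

At the position on a double-bonded chain carbon bound to a double-bonded chain carbon, 4-hydroxy-3-methoxyphenyl in place of 3-hydroxyphenyl gives a 2.2-fold lower number from compound 2 to compound 3 (0.34 log units; beyond the scatter) in this assay and so shows that this ring change alone can move the number by a modest margin. The further comparison gives a 1.1-fold lower number from compound 1 to compound 3 (0.03 log units; within the scatter) and leaves 4-hydroxy-3-methoxyphenyl and 3-ethyl-4,5-dimethoxyphenyl indistinguishable here, so among these three compounds only the 3-hydroxyphenyl of compound 2 stands apart. Nothing at hand accounts for this shift.

The compounds shown do not separate any contribution of the methoxy group from that of the moved hydroxyl. From the compounds shown here alone, what an amine or a carboxylic acid on this ring, or a longer chain in place of the ethyl, would do to the number also remains open.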